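Resolving compound 1: one enantiomer of the inactive racemate

A few compounds are considered here, and "the series" means these few. Any claim that something is new, unique, unknown or untested is made for them only; others in the source may bear on it.

Measured so far in an in vitro functional assay on CHO-CREluc cells for antagonist activity at growth hormone secretagogue receptor type 1 (Homo sapiens), read by a luciferase reporter, with a stated time of 4 h; a lower number here means a stronger inhibitor, a higher number a weaker inhibitor:
compound 1, `CN1CCN(CC(=O)NC2(c3ccc(Cl)cc3)C(=O)Nc3cc(Cl)c(Cl)cc32)CC1`, > 10000 nM
compound 2, `CCN1CCC(CC(=O)NC2(c3ccc(Cl)c(Cl)c3)C(=O)Nc3cc(Cl)cc(Cl)c32)CC1`, 1 nM
compound 3, `CN(C)CCN(C)CC(=O)NC1(c2ccc(Cl)cc2)C(=O)Nc2cc(Cl)c(Cl)cc21`, > 10000 nM

Compound 1 stands at a limit of the assay: in this assay compound 1 gives > 10000 nM, which is a limit and not a number. Compound 3 likewise gives only a limit, > 10000 nM. For the measured compounds named here, compound 2 gives 1 nM, but it differs from compound 1 in more than one place and no single step connects the two. Going by the values given here, the only single-point step among the measured compounds, a step that the two limits leave unreadable from compound 1 to compound 3, has no readable size because of the limit of > 10000 nM in this assay, at which 2 of the 3 values shown sit.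

Compound 4, `CN1CCN(CC(=O)N[C@]2(c3ccc(Cl)cc3)C(=O)Nc3cc(Cl)c(Cl)cc32)CC1`, is the next compound: the two compounds have the same atoms and bonds; at least one stereo element is drawn with a configuration in one of them and without one in the other: 1 of 1 stereo elements differ; a stereocentre at a saturated ring carbon is drawn without a configuration in compound 1 and S in compound 4. Compound 1 is thus the racemate and compound 4 one of its two components. Among the compounds with values here, no measured step concerns a stereocentre, so nothing can be borrowed for the size of this change. What can be said rests on compound 1 alone: a racemate reported at > 10000 nM leaves little room for either component to be a strong inhibitor, and the same limit is the most probable outcome.

Compound 4 is therefore expected to give 20000 nM, with a range of 8000 nM to 100000 nM. The expected step is a step that the limit leaves unreadable from compound 1 to compound 4, which is most likely to be reported again only as a limit.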

Compound 4, half-maximal inhibitory concentration: 47 nM
The estimate for compound 4 lay 430-fold (2.63 log units) above the measured number; measured number outside the range, below it.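

Drawing the stereocentre at a saturated ring carbon as S goes with an at least 210-fold lower number from compound 1 to compound 4 (2.32 log units; beyond the scatter), and this step can be tied to that stereocentre alone because nothing else separates the pair: the fact that one of compounds 1 and 4 is drawn with a defined configuration and the other without, at the place where they differ

Compound 1 gives > 10000 nM, which is a limit and not a number. With the S configuration drawn, the 4-methylpiperazin-1-yl side chain on this core does not rule out inhibition in this assay, where compound 4 gives 47 nM, so the reading of the racemate does not carry over to this component.

From the compounds shown here alone, what the R enantiomer of compound 1 gives remains open, so the size of the difference between the two enantiomers cannot yet be stated. Going by these compounds, it is also open whether the S configuration gives a readable number with other groups at this place, such as a morpholin-4-yl ring in place of 4-methylpiperazin-1-yl or the (2-(dimethylamino)ethyl)(methyl)amino chain of compound 3.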